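Fluoro for methyl on a para-substituted ring in three series

The source may report more compounds than this note shows. Statements on the series, on what has been measured and on what is new or still open speak of the compounds shown alone.

Compound 1 `C/C(=C\c1cc(-c2ccc(C)nc2)co1)C(N)=O` and compound 2 `C/C(=C\c1cc(-c2ccc(F)nc2)co1)C(N)=O` share one core; compound 3 `C/C(=C\c1ccc(-c2ccc(C)cc2)o1)C(N)=O` rests on another core, and the difference between the two cores is not broken down here. Compound 4 `C/C(=C\c1ccc(-c2ccc(F)cc2)o1)C(N)=O` is not yet measured.

In a functional assay on T-24 cells (Homo sapiens) for cytotoxicity, read by CCK-8 assay, with a stated time of 24 h (on this read-out higher numbers stand for weaker inhibition and lower numbers for stronger inhibition), compound 1 gives > 50000 nM, a limit of the assay. Compound 2 gives > 50000 nM, also a limit. Compound 3 gives > 50000 nM, again a limit. The step that the two limits leave unreadable from compound 1 to compound 2 is therefore unreadable; the change is fluoro in place of methyl on an aromatic carbon. The change fluoro in place of methyl on an aromatic carbon is the same kind of change, but its place is a six-membered aromatic ring of carbon only, whereas in compound 1 the ring carries one nitrogen and the group sits next to the ring nitrogen.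

Because (the limit of > 50000 nM in this assay, at which 3 of the 3 values shown sit), compound 4 is expected to give a step that the limit leaves unreadable from compound 3 to compound 4. Compound 4 is estimated at 80000 nM, likely between 30000 nM and 200000 nM.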

Compound 4, half-maximal inhibitory concentration: 3320 nM
The estimate for compound 4 lay 24-fold (1.38 log units) above the measured number; measured number below the stated range.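

In this assay, fluoro in place of methyl on an aromatic carbon gives an at least 15-fold lower number from compound 3 to compound 4 (1.17 log units; beyond the scatter), so on the core of compound 3 this change has a large effect on the read-out. The same change on the shared core of compound 1 and compound 2 cannot be read, because both of those values are limits: the limit of > 50000 nM in this assay, at which 3 of the 4 values shown sit. Carrying the change from one core to the other is therefore neither supported nor ruled out, and the result holds for this one pair only.

The compounds shown leave open whether chloro or an amine in the same place would act as fluoro does on either core. They also leave open which of the differences between the two cores decides the outcome.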